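Fluoro Enters a New Carbon of Compound 2

This account rests on a few compounds, and the source may have more. Where it says the series, first, only, none or still open, it means among the compounds named here.

In an ADME assay for solubility, in simulated intestinal fluid (a lower number here means a less soluble compound, a higher number a more soluble compound), compound 2 `O=C(Nc1cccn(Cc2ccccc2)c1=O)c1ccc2c(c1)B(O)OC2` gives 3 ug/mL and compound 1 `O=C(Nc1cccn(Cc2ccccc2)c1=O)c1ccc2c(c1F)B(O)OC2` gives 4 ug/mL so the two stand within the scatter of each other. Compound 3 `O=C(Nc1cccn(Cc2ccccc2)c1=O)c1cc(F)c2c(c1)B(O)OC2` has not yet been measured. The change from compound 2 fluoro in place of hydrogen on an aromatic carbon is fluoro in place of hydrogen on an aromatic carbon, ortho to a fused ring and meta to a large group. Among the measured compounds shown here, the one measured step of this kind is a 1.3-fold lower number from compound 1 to compound 2 (0.12 log units; within the scatter) and it exchanges the same two atoms in the other direction, on a different carbon. On that single step, no change beyond the scatter is expected. The estimated move is a 1.3-fold higher number from compound 2 to compound 3 (0.12 log units; within the scatter) and it stays small. Compound 3 is expected at 4 ug/mL within an estimated range of 2 ug/mL to 8 ug/mL on this reading.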

Compound 3, solubility: 8 ug/mL
Beside the measured number, compound 3's estimate is 2.0-fold (0.30 log units) below it, and the stated range covers the measured number.
By their numbers in this assay, from the lowest: compounds 2, 1 and 3 (each within the scatter of the next, the first and the last beyond it).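

In this assay, fluoro in place of hydrogen on this aromatic carbon, ortho to a fused ring and meta to a large group, gives a modest change beyond the scatter, a 2.7-fold higher number from compound 2 to compound 3 (0.43 log units; beyond the scatter), whereas the exchange of the same two atoms on the other carbon stays within it, a 1.3-fold lower number from compound 1 to compound 2 (0.12 log units; within the scatter). The exchange therefore does not read alike on the two carbons of the shared core, although compound 1 and compound 3 stand within the scatter of each other. Nothing given here explains the step.

On these data alone, whether a chloro, a methoxy or an amine on this carbon would move the number as fluoro does remains open. So does the result of carrying fluoro on both carbons at once.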